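A few compounds are considered here, and "the series" means these few. Any claim that something is new, unique, unknown or untested is made for them only; others in the source may bear on it.

In an assay for positive allosteric modulation of metabotropic glutamate receptor 3 (Rattus norvegicus) (a higher number here means that more compound is needed for the effect, a lower number that less compound is needed), three compounds have been measured so far. Compound 1 `Cc1ncc(OCCCCOc2ccc(C(=O)CC(C)(C)C)c(O)c2C)cc1C(=O)O` gives 79 nM. Compound 2 `Cc1c(OCCCCOc2cncc(C(=O)O)c2)ccc(C(=O)CC(C)(C)C)c1O` gives 180 nM, and compound 3 `Cc1ccc(C(=O)O)cc1OCCCCOc1ccc(C(=O)CC(C)(C)C)c(O)c1C` gives 892 nM. Among these three numbers compound 2 stands second highest: compound 1 lies nearest, the step of a 2.3-fold higher number from compound 1 to compound 2 (0.36 log units; beyond the scatter) being the smallest one here, while compound 3 lies furthest, with a 5.0-fold higher number from compound 2 to compound 3 (0.70 log units; beyond the scatter). The step of an 11-fold higher number from compound 1 to compound 3 (1.05 log units; beyond the scatter) is larger still.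

The unmeasured compound 4 `Cc1c(OCCCCOc2ccc(F)c(C(N)=O)c2)ccc(C(=O)CC(C)(C)C)c1O` differs from compound 2 in one place: 3-carbamoyl-4-fluorophenyl in place of 5-carboxypyridin-3-yl on an oxygen on a saturated carbon. Among the compounds with values here, the step that bears most directly on this change is the one from compound 2 to compound 3, where the ring with one hetero atom was likewise exchanged for a ring of carbon only, and the number rose by a modest amount. Here the carboxylic acid is also replaced by a carboxamide and a fluorine is added, so a step of similar or somewhat larger size, towards a higher number, is expected, a 6.7-fold higher number from compound 2 to compound 4 (0.82 log units; beyond the scatter). For compound 4 the expected value in this assay is therefore 1200 nM, with a range from 400 nM to 4000 nM.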

Compound 4, half-maximal effective concentration: "not active" (no number reported)
Nothing numeric was reported for compound 4; no gap can be computed for the estimate.
By their numbers in this assay, from the lowest: compound 1; then compound 2; then compound 3.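

Compound 4 is reported as "not active" in this assay, with no number, so the step from compound 2 to compound 4 cannot be read. Nothing shown here offers an explanation for this result.
The compounds shown leave open which part of the change to 3-carbamoyl-4-fluorophenyl goes with this outcome.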